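Replacing an aromatic ring on a weak starting point

The compounds below may be only part of what the source reports. "The series", "measured", "known", "first", "only" and "open" are said of these compounds alone.

Measured so far in a functional assay on NCI-H1993 cells (Homo sapiens) for inhibition, read by CCK-8 assay, with a stated time of 72 h; a higher number here means a weaker inhibitor, a lower number a stronger inhibitor:
- Compound 1 `COC(=O)c1ccc(-c2cnc3ncn(C(C)c4ccc5ncccc5c4C)c3n2)cc1F`: "not determined" (no result reported)
- Compound 2 `CN(C)c1cccc(-c2cnc3ncn(Cc4ccc5ncccc5c4)c3n2)c1`: > 10000 nM

Compound 1 offers no number for comparison. In this assay compound 2 gives > 10000 nM, which is a limit of the assay and not a number. Going by these compounds, it therefore marks a very weak inhibitor, but its true value remains unknown.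

Compound 3 `C1=C(c2cnc3ncn(Cc4ccc5ncccc5c4)c3n2)CCNC1` keeps the shared core and replaces the 3-(dimethylamino)phenyl group of compound 2 with a six-membered non-aromatic ring (a group of 6 heavy atoms (5 carbon, 1 nitrogen; one six-membered non-aromatic ring with 1 hetero atom) in place of a group of 9 heavy atoms (8 carbon, 1 nitrogen; one six-membered aromatic ring of carbon only), on an aromatic carbon). The change sits on an aromatic carbon of the core. Within the data shown here, no measured pair shows what such a swap does here. A modest move towards stronger inhibition is expected, although compound 3 may also end up reported only as a limit. The expected change is an at least 3.3-fold lower number from compound 2 to compound 3 (0.52 log units; beyond the scatter). For compound 3 the estimated half-maximal inhibitory concentration is 3000 nM, with an expected range of 300 nM to 10000 nM.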

Compound 3, half-maximal inhibitory concentration: 6660 nM
Estimate against measurement, compound 3: 2.2-fold (0.35 log units) below; the range from low to high includes it.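

In this assay compound 3 gives 6660 nM as a measured number, so this aromatic carbon of the core can carry a six-membered non-aromatic ring with 1 hetero atom and still give a reading. The 3-(dimethylamino)phenyl group of compound 2 gave only a limit. The swap amounts to an at least 1.5-fold lower number from compound 2 to compound 3 (0.17 log units; that floor lies within the scatter) and the true step may be larger. Compound 2 stands at a limit of the assay and not at a number, which is why this step is only a floor: the limit of > 10000 nM in this assay, at which 1 of the 3 values shown sits.

The swap changes the aromatic ring, the double bond and the hydrogen-bond donor all at once, and nothing here separates their shares in the result. Also open, going by these compounds, is how a saturated piperidine ring, or an open chain ending in an amine, would read at this position.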